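The source may report more compounds than this note shows. Statements on the series, on what has been measured and on what is new or still open speak of the compounds shown alone.

Of the compounds shown here, three built on one shared core have been tested in a functional assay on SK-MEL-28 cells (Homo sapiens) for cytotoxicity, read by MTT assay; on this read-out higher numbers stand for weaker inhibition and lower numbers for stronger inhibition. Compound 1 `O=S(=O)(NCCCNc1nccc(-c2c(-c3cccc(F)c3)nc3sccn23)n1)c1ccc(Br)cc1` carries a bromo group on its outer ring and gives 9400 nM. Compound 3 `O=S(=O)(NCCCNc1nccc(-c2c(-c3cccc(F)c3)nc3sccn23)n1)c1ccc(Cl)cc1`, with chloro in place of bromo on an aromatic carbon, gives 8450 nM, and the step of a 1.1-fold lower number from compound 1 to compound 3 (0.05 log units; within the scatter) stays within the usual scatter. Compound 2 `O=S(=O)(NCCCNc1nccc(-c2c(-c3cccc(F)c3)nc3sccn23)n1)c1ccc(F)cc1` carries fluoro in that position and gives > 20000 nM, which is a limit of the assay and not a number (the limit of > 20000 nM in this assay, at which 1 of the 3 values shown sits). The steps of an at least 2.1-fold higher number from compound 1 to compound 2 (0.32 log units; beyond the scatter) and an at least 2.3-fold lower number from compound 2 to compound 3 (0.37 log units; beyond the scatter) both run the same way, so compound 2 stands as the weakest of the three.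

Compound 4 `O=C(NCCNc1nccc(-c2c(-c3cccc(F)c3)nc3sccn23)n1)c1ccc(Cl)cc1` differs from compound 2 in a broader way: ((4-chlorophenyl)carbonyl)amino in place of (((4-fluorophenyl)sulfonyl)amino)methyl on a saturated chain carbon, two bonds along the chain from a nitrogen on an aromatic ring. One part of this change, chloro for fluoro on the aromatic ring, is mirrored by the measured step of an at least 2.3-fold lower number from compound 2 to compound 3 (0.37 log units; beyond the scatter), which lowered the number beyond the scatter. For the measured compounds named here, the remaining parts, sulfonyl exchanged for carbonyl and an altered linking chain, have no measured counterpart among the three compounds. The expected step is therefore an at least 2.2-fold lower number from compound 2 to compound 4 (0.34 log units; beyond the scatter) in this assay, leaning on the halogen exchange alone. Compound 4 is accordingly estimated to give 9000 nM, in a range from 3000 nM to 30000 nM.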

Compound 4, half-maximal inhibitory concentration: 8160 nM
Beside the measured number, compound 4's estimate is 1.1-fold (0.04 log units) above it; low and high end bracket the measured number.
By their numbers in this assay, from the lowest: compounds 4, 3 and 1 (each within the scatter of the next). At a limit, above all of these: compound 2.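

Compound 4 shows that this position accepts a carbonyl in place of the sulfonyl, together with an altered linking chain, without any change beyond the scatter in this assay: with the chloro group kept on the outer ring, the step is a 1.0-fold lower number from compound 3 to compound 4 (0.02 log units; within the scatter). The comparison with the bromo compound agrees, at a 1.2-fold lower number from compound 1 to compound 4 (0.06 log units; within the scatter), so the sulfonyl group is not needed to reach this level of activity among the compounds shown, while the step of an at least 2.4-fold lower number from compound 2 to compound 4 (0.38 log units; beyond the scatter) is the one clear shift, and in it the halogen changes along with the carbonyl and the chain. Compound 2 enters that last step only as a limit of the assay and not as a number: the limit of > 20000 nM in this assay, at which 1 of the 4 values shown sits.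

The carbonyl and the altered chain arrive together in compound 4, and the compounds shown cannot tell whether each leaves the number alone or whether the two pull in opposite directions and cancel. Also open, on these data alone, is how a carbonyl compound with a longer chain, or one with an amine or a carboxylic acid in place of the outer halogenated ring, would read in this assay.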